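A few compounds are considered here, and "the series" means these few. Any claim that something is new, unique, unknown or untested is made for them only; others in the source may bear on it.

Measured compounds
Compound 1 `CC(C)(C)c1cc(NC(=O)Nc2ccc(Nc3ncnc4c3OCCN4)c(F)c2)no1`: 21 nM
Compound 2 `COc1cc(NC(=O)Nc2cc(C(C)(C)C)on2)ccc1Nc1ncnc2c1OCCN2`: 22 nM

Working notes. Both values come from an assay on isolated protein for inhibition of proto-oncogene tyrosine-protein kinase receptor Ret (Homo sapiens), read by 33P incorporation, with stated times of 15 min and 40 min; on this read-out higher numbers stand for weaker inhibition and lower numbers for stronger inhibition. On the two numbers at hand compound 2 sits at the higher end, but its nearest neighbour compound 1 lies within the scatter of it: the step of a 1.0-fold higher number from compound 1 to compound 2 (0.02 log units; within the scatter) shows no difference that can be read as real, so compound 1 and compound 2 are to be treated as equivalent in this assay.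

Next candidate is compound 3 `CC(C)(C)c1cc(NC(=O)Nc2ccc(Nc3ncnc4c3OCCN4)c(O)c2)no1`. Compared with compound 2 the change is hydrogen in place of methyl on an oxygen on an aromatic ring. Among the compounds with values here, no measured pair shows a methyl removed from an oxygen on an aromatic ring, so there is no direct precedent for this step. Within the data shown here, the only step on hand, a 1.0-fold higher number from compound 1 to compound 2 (0.02 log units; within the scatter), is a swap at the same ring position that left the number unchanged within the scatter, which suggests this part of the molecule tolerates small changes without much effect on inhibition.

Accordingly compound 3 is expected to land close to compound 2, with a step of a 1.1-fold higher number from compound 2 to compound 3 (0.06 log units; within the scatter) that need not exceed the scatter. The estimate for compound 3 in this assay is 25 nM, with a range from 8 nM to 80 nM.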

Compound 3, half-maximal inhibitory concentration: 25 nM
Beside the measured number, compound 3's estimate shows no gap at the digits printed, and the stated range covers the measured number.
By their numbers in this assay, from the lowest: compounds 1, 2 and 3 (each within the scatter of the next).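

In this assay, within the data shown here, the first methoxy to hydroxy change gives a 1.1-fold higher number from compound 2 to compound 3 (0.06 log units; within the scatter) and so adds a case in which hydrogen in place of methyl on an oxygen on an aromatic ring cannot be told apart from no change. The second new comparison, a 1.2-fold higher number from compound 1 to compound 3 (0.08 log units; within the scatter), where a fluoro gives way to a hydroxy, reads the same way and closes the set of pairs among the three compounds. Fluoro, methoxy and hydroxy at this aromatic carbon are therefore equivalent in this assay, and no information is at hand on what lies behind this equivalence.

The compounds shown leave open whether an amine, a carboxylic acid, a plain hydrogen or a longer chain such as propoxy at this aromatic carbon would stay within the scatter of these three or would finally give a step that can be read. They also leave open whether the same equivalence would hold with a group other than the tert-butyl on the far side of the urea.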